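Methylating the Anilino Nitrogen of Compound 1

A few compounds are considered here, and "the series" means these few. Any claim that something is new, unique, unknown or untested is made for them only; others in the source may bear on it.

Compound 1 `Cc1c(Nc2ccc(S(C)(=O)=O)cc2F)ncnc1O[C@H]1CC[C@]2(CC1)COC(C)(C)C2` gives 13 nM in a functional assay on HEK293 cells for agonist activity at Glucose-dependent insulinotropic receptor (Homo sapiens), read by HTRF and cAMP accumulation, with a stated time of 30 min (a higher number here means that more compound is needed for the effect, a lower number that less compound is needed), the lowest of the three numbers measured. Compound 2 `Cc1c(Nc2ccc(C(=O)N(C)C)cc2F)ncnc1O[C@H]1CC[C@]2(CC1)COC(C)(C)C2` gives 33 nM, and compound 3 `Cc1c(Nc2ccc(S(C)(=O)=O)cc2)ncnc1O[C@H]1CC[C@]2(CC1)COC(C)(C)C2` gives 139 nM. Both measured steps moved upward from compound 1: a 2.5-fold higher number from compound 1 to compound 2 (0.40 log units; beyond the scatter) and an 11-fold higher number from compound 1 to compound 3 (1.03 log units; beyond the scatter). Compound 4 `Cc1c(O[C@H]2CC[C@]3(CC2)COC(C)(C)C3)ncnc1N(C)c1ccc(S(C)(=O)=O)cc1F` differs from compound 1 by methyl in place of hydrogen on a nitrogen on an aromatic ring. Neither measured step touches this nitrogen; both alter the aromatic ring it carries, so nothing measured bears directly on the new change. Because a 2.5-fold higher number from compound 1 to compound 2 (0.40 log units; beyond the scatter) and an 11-fold higher number from compound 1 to compound 3 (1.03 log units; beyond the scatter) both left the lowest number behind, a higher number is also expected for compound 4, a 7.7-fold higher number from compound 1 to compound 4 (0.89 log units; beyond the scatter), with its size uncertain. Compound 4 is estimated at 100 nM, within 20 nM to 600 nM.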

Compound 4, half-maximal effective concentration: > 1000 nM
Compound 4: only a limit was reported; the forecaster's own chance of this, stated with the estimate: 10%; at least 10-fold (1.00 log units) between middle value and limit.
By their numbers in this assay, from the lowest: compound 1; then compound 2; then compound 3. At a limit, above all of these: compound 4.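

Methyl in place of hydrogen on this nitrogen gives an at least 76-fold higher number from compound 1 to compound 4 (1.88 log units; beyond the scatter), the first change shown at the nitrogen itself rather than on the aromatic ring it carries. Compound 4 reaches only a limit of the assay, not a number: the limit of > 1000 nM in this assay, at which 1 of the 4 values shown sits. A single added carbon at this nitrogen therefore moves the number further than either earlier change on the ring.

The compounds shown cannot separate the loss of the hydrogen from the arrival of the methyl. From the compounds shown here alone, how an ethyl or an acetyl group on this nitrogen would read remains open.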